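Demethylation of the Aryl Ether in Compound 2

This account rests on a few compounds, and the source may have more. Where it says the series, first, only, none or still open, it means among the compounds named here.

The compounds were tested in a functional assay on U-251 cells (Homo sapiens) for inhibition, read by sulforhodamine B assay, with a stated time of 48 h; on this read-out lower numbers stand for higher toxicity in this test and higher numbers for lower toxicity in this test. Compound 1 `O=C(Nc1cccc(-n2cc(-c3ccncc3)c(-c3ccc(Cl)c(O)c3)n2)c1)Nc1cccc(C(F)(F)F)c1` reports only a limit in this assay, > 32500 nM. Going by the values given here, compound 2 `COc1cc(-c2nn(-c3cccc(NC(=O)Nc4cc(C(F)(F)F)cc(C(F)(F)F)c4)c3)cc2-c2ccncc2)ccc1Cl` gives the only numerical value in this assay, 3180 nM, and so stands alone as a number. The result of compound 1 is a limit (the limit of > 32500 nM in this assay, at which 1 of the 2 values shown sits). Compound 3 `O=C(Nc1cccc(-n2cc(-c3ccncc3)c(-c3ccc(Cl)c(O)c3)n2)c1)Nc1cc(C(F)(F)F)cc(C(F)(F)F)c1` has not yet been measured in this assay. It differs from compound 2 by hydrogen in place of methyl on an oxygen on an aromatic ring, so that the 4-chloro-3-methoxyphenyl of compound 2 becomes the 4-chloro-3-hydroxyphenyl that compound 1 also carries. Among the compounds with values here, no two measured compounds differ in this one place alone, so the size of the step cannot be read off and must be expected. Compound 1 carries the same hydroxy group, with a different urea substituent, and reaches only the limit. Compound 3 is therefore expected to shift by a 3.1-fold higher number from compound 2 to compound 3 (0.50 log units; beyond the scatter) toward lower toxicity in this test. Compound 3 is estimated at 10000 nM, with a range from 3000 nM to 32500 nM, and a fair chance that this assay again reports only a limit.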

Compound 3, concentration lethal to 50% of the cells: 2800 nM
Estimate against measurement, compound 3: 3.6-fold (0.55 log units) above, outside the stated range (below it).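

In this assay, going by these compounds alone, the exchange of methoxy for hydroxy gives a 1.1-fold lower number from compound 2 to compound 3 (0.06 log units; within the scatter) and so, with the two trifluoromethyl groups of compound 2 in place, this oxygen on an aromatic ring carries either a methyl or a hydrogen with no step that stands out from the scatter. The large change lies at another place, where trifluoromethyl in place of hydrogen on an aromatic carbon gives an at least 11-fold lower number from compound 1 to compound 3 (1.06 log units; beyond the scatter) and shows that the 4-chloro-3-hydroxyphenyl group does not by itself go with the high number that compound 1 had suggested. Compound 1 stands at a limit and not at a number, so the true size of this step stays unknown: the limit of > 32500 nM in this assay, at which 1 of the 3 values shown sits.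

The compounds shown leave open whether the trifluoromethyl step would be of similar size with methoxy in place of hydroxy, as the one pair that shows it carries hydroxy. They also leave open whether a longer chain on this oxygen, such as ethyl, or an amine in place of the hydroxy would leave the number in this assay where it stands for compound 2 and compound 3.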